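Acid-tailed thioether variant of a weak inhibitor

The source may hold more compounds than are shown below. What is called first, only, known or untested is meant among the compounds shown, and "the series" means these compounds.

Compound 2 `CCCCCCCCOc1cc(-c2ccccc2)c(-c2ccccc2)nn1` stands second highest among three numbers in an assay on microsomes from liver for inhibition of sterol O-acyltransferase 1 (Rattus norvegicus) (on this read-out lower numbers stand for stronger inhibition and higher numbers for weaker inhibition), with a value of 104000 nM. Compound 1 `CCCCCCn1nc(-c2ccccc2)c(-c2ccccc2)cc1=O` gives 57000 nM and compound 3 `CCCCCCCCCOc1cc(-c2ccccc2)c(-c2ccccc2)nn1` gives 180000 nM; the step of a 1.7-fold higher number from compound 2 to compound 3 (0.24 log units; within the scatter) lies within the scatter, as does the gap between compound 2 and compound 1. Compound 4 `O=C(O)CCCCCSc1cc(-c2ccccc2)c(-c2ccccc2)nn1` arises from compound 2 by (5-carboxypentyl)sulfanyl in place of octyloxy on an aromatic carbon. Among the compounds with values here, the only measured step concerns a methyl added to a chain, not the swap of oxygen for sulfur or the added carboxylic acid, so nothing measured points to a direction in this assay. For compound 4 the expected step is a 1.0-fold lower number from compound 2 to compound 4 (0.02 log units; within the scatter), none beyond the scatter. Compound 4 is therefore estimated at 100000 nM, with a range from 25000 nM to 400000 nM.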

Compound 4, half-maximal inhibitory concentration: > 300000 nM
Compound 4 ended at the assay's limit; the forecaster's own chance of this, stated with the estimate: 25%; middle value at least 3.0-fold (0.47 log units) away from the limit.
By their numbers in this assay, from the lowest: compounds 1, 2 and 3 (each within the scatter of the next, the first and the last beyond it). At a limit, above all of these: compound 4.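

Unlike the added methyl on the chain, swapping the group on this aromatic carbon moves the result in this assay beyond the scatter: (5-carboxypentyl)sulfanyl in place of octyloxy gives an at least 2.8-fold higher number from compound 2 to compound 4 (0.46 log units; beyond the scatter). Compound 4 reads > 300000 nM, which is a limit of the assay and not a number: the limit of > 300000 nM in this assay, at which 1 of the 4 values shown sits. The step belongs to the whole group, since the linking atom and the chain end change together.

Which of these two changes carries the step stays open. An octylsulfanyl group and a (5-carboxypentyl)oxy group would each separate them.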